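This account rests on a few compounds, and the source may have more. Where it says the series, first, only, none or still open, it means among the compounds named here.

Measured so far: compound 3 `COc1cccc(OC)c1OCCNCCOc1ccccc1OCc1cccc(C)c1` gives 8.2; compound 2 `COc1cccc(OC)c1OCCNCCOc1ccccc1OCc1ccc(Cl)cc1` gives 8.06; compound 1 `COc1cccc(OC)c1OCCNCCOc1ccccc1OCc1ccccc1Cl` gives 7.52, all in a functional assay on spleen for antagonist activity at Alpha-1B adrenergic receptor (Rattus norvegicus); on this read-out higher numbers stand for higher potency (the scale is a negative logarithm) and lower numbers for lower potency.

Compound 3 has the highest of the three numbers, though compound 2 lies within the scatter of it, as a number 0.14 log units higher from compound 2 to compound 3 (within the scatter) shows. Compound 4 `COc1cccc(OC)c1OCCNCCOc1ccccc1OCc1ccccc1[N+](=O)[O-]` carries 2-nitrophenyl in place of 3-methylphenyl on a saturated chain carbon bound to an oxygen on an aromatic ring. Within the data shown here, the steps that bear on this are a number 0.68 log units higher from compound 1 to compound 3 (beyond the scatter) and a number 0.54 log units higher from compound 1 to compound 2 (beyond the scatter), both starting from the 2-chlorophenyl compound 1, which gave the lowest number. A group placed in the same way on the ring enters again in compound 4, so a modest drop in this assay is expected, roughly a number 0.60 log units lower from compound 3 to compound 4 (beyond the scatter). Compound 4 is therefore estimated at 7.6, within 7.1 to 8.2.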

Compound 4, negative logarithm of the antagonist equilibrium constant: 8.56
For compound 4 the middle estimate is 0.96 log units below the measured one; the measured number lies above the stated range.
By their numbers in this assay, from the lowest: compound 1; then compounds 2 and 3 (each within the scatter of the next); then compound 4.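

In this assay, the low number of the 2-chlorophenyl compound does not carry over to 2-nitrophenyl: nitro in place of chloro gives a number 1.04 log units higher from compound 1 to compound 4 (beyond the scatter). The 2-nitrophenyl group also exceeds the other two rings, with a number 0.36 log units higher from compound 3 to compound 4 (beyond the scatter) and a number 0.50 log units higher from compound 2 to compound 4 (beyond the scatter), so among these four compounds the group matters and not only where it sits on the ring.

Nothing measured here explains this difference. Also open, on these data alone, is where 2-aminophenyl, 2-methylphenyl, 3-nitrophenyl or 4-nitrophenyl would fall.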